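Clearance notes: 4-bromophenyl to 5-methylpyridin-2-yl

The source may report more compounds than this note shows. Statements on the series, on what has been measured and on what is new or still open speak of the compounds shown alone.

Values in an ADME assay on microsomes from liver (Homo sapiens) for metabolic stability; on this read-out higher numbers stand for fast clearance and lower numbers for slow clearance:
- compound 1 `Cc1ccc([C@H](C)NC(=O)Cn2nnc3ccccc3c2=O)cc1`: < 9.9 mL/min/kg (a limit)
- compound 2 `C[C@H](NC(=O)Cn1nnc2ccccc2c1=O)c1ccc(F)cc1`: 31 mL/min/kg
- compound 3 `C[C@H](NC(=O)Cn1nnc2ccccc2c1=O)c1ccc(Br)cc1`: < 9.9 mL/min/kg (a limit)

Compound 3 stands at < 9.9 mL/min/kg, which is a limit and not a number. Its place in the series is the limit of < 9.9 mL/min/kg in this assay, at which 2 of the 3 values shown sit.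

Compound 4 `Cc1ccc([C@H](C)NC(=O)Cn2nnc3ccccc3c2=O)nc1` carries 5-methylpyridin-2-yl in place of 4-bromophenyl on the saturated chain carbon bound to the amide-type nitrogen: 5-methylpyridin-2-yl in place of 4-bromophenyl on a saturated chain carbon bound to an amide-type nitrogen and a saturated chain carbon.

Among the compounds with values here, no measured step exchanges the ring itself, so the evidence is indirect. Swaps on the aromatic carbon do register, with an at least 3.1-fold higher number from compound 1 to compound 2 (0.49 log units; beyond the scatter) and an at least 3.1-fold lower number from compound 2 to compound 3 (0.49 log units; beyond the scatter), while a step that the two limits leave unreadable from compound 1 to compound 3 cannot be sized. Within the data shown here, compound 2 is the one compound that goes against a uniformly low reading. Compound 1 also carries a methyl group on its aromatic ring, and its < 9.9 mL/min/kg is a limit. Among the measured compounds shown here, on that basis, a small upward step or none beyond the scatter is expected in this assay, though the new ring has no measured precedent. The estimated step is an at least 1.2-fold higher number from compound 3 to compound 4 (0.08 log units; that floor lies within the scatter), and it is expected to stay small. For compound 4 the estimated value is 12 mL/min/kg, with an expected range of 6 mL/min/kg to 28 mL/min/kg.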

Compound 4, clearance: < 9.9 mL/min/kg
Compound 4 gave a limit, no number (the forecaster's own chance of this, stated with the estimate: 45%); at least 1.2-fold (0.08 log units) between middle value and limit.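

In this assay compound 4 gives < 9.9 mL/min/kg, which is a limit of the assay and not a number. The position on the saturated chain carbon bound to an amide-type nitrogen and a saturated chain carbon now has a measured exchange of the ring itself, and 5-methylpyridin-2-yl, with its one hetero atom and one hydrogen-bond acceptor, gives a reading clearly apart from that of the 4-fluorophenyl compound, with an at least 3.1-fold lower number from compound 2 to compound 4 (0.49 log units; beyond the scatter). The steps that link compound 4 to compound 1 and compound 3 cannot be read, so any effect of the ring nitrogen stays unsized, and compound 2 remains the only compound against a uniformly low reading: the limit of < 9.9 mL/min/kg in this assay, at which 3 of the 4 values shown sit.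

The compounds shown leave open whether the low reading follows the ring nitrogen or the methyl group, and 5-fluoropyridin-2-yl, set against compound 2, or unsubstituted pyridin-2-yl, set against compound 4, would separate the two. Also open, on these data alone, is any ranking among compound 1, compound 3 and compound 4, since each of them carries only a limit on this read-out.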